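The source may hold more compounds than are shown below. What is called first, only, known or untested is meant among the compounds shown, and "the series" means these compounds.

Working notes on the series. Compound 1, `CCC(C)n1cnc2c(NCc3ccc(C(=O)Nc4ccccc4N)cc3)nc(Cl)nc21`, gives 75.1% in a functional assay on HCT-116 cells (Homo sapiens) for antiproliferative activity, read by CCK-8 assay, with a stated time of 72 h, tested at 8 uM; a higher number here means a stronger effect of the compound at the concentration tested, a lower number a weaker effect. Compound 2, `Nc1ccccc1NC(=O)c1ccc(Cn2cnc3c(Nc4ccccc4)nc(Cl)nc32)cc1`, gives 83.5% in this assay, and compound 3, `Nc1ccccc1NC(=O)c1ccc(COCNc2nc(Nc3ccccc3)c3ncn(C4CCCC4)c3n2)cc1`, gives 76.9%. The number of compound 1 is the lowest of the three shown, yet its gaps to compound 3 and to compound 2 both lie within the usual scatter of such measurements, so the three compounds are not separated on these data.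

Compound 4, `Nc1ccccc1NC(=O)c1ccc(CNc2nc(Cl)nc3c2ncn3Cc2ccccc2)cc1`, has not been measured. It differs from compound 1 in one place: benzyl in place of sec-butyl on an aromatic nitrogen. Among the measured compounds shown here, no pair of measured compounds differs in this one place alone, so the size of this step has no direct reference in the data. Compound 2 and compound 3 carry other groups at this ring nitrogen and differ from compound 1 elsewhere too, and their numbers stay within the scatter of compound 1. For compound 4 the step is therefore expected to stay within the scatter, with no clear direction, as a number 0.9 percentage points higher from compound 1 to compound 4 (within the scatter). Compound 4 is estimated at 76%, in a range from 64% to 88%.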

Compound 4, a percentage reported as inhibition, at one concentration (the size of the read-out at that concentration, not a potency): 11.5%
Beside the measured number, compound 4's estimate is 64.5 percentage points above it, and the stated range ends above it.
By their numbers in this assay, from the lowest: compound 4; then compounds 1, 3 and 2 (each within the scatter of the next).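

In this assay, among the compounds shown here, benzyl in place of sec-butyl on the aromatic nitrogen gives a number 63.6 percentage points lower from compound 1 to compound 4 (beyond the scatter) and so this position, which had no one-place reference among the earlier compounds, proves far from indifferent to the group it carries. The step adds one six-membered aromatic ring of carbon only and changes neither the hydrogen-bond donors nor the acceptors counted for the group, yet it takes compound 4 well outside the scatter of compound 1. Nothing available bears on the reason for this step.

From the compounds shown here alone, whether the drop follows the aromatic ring itself or simply the larger group remains open. An isopropyl, n-hexyl, cyclohexylmethyl or 2-phenylethyl group on this nitrogen, with the rest of compound 1 unchanged, would help to separate these two readings.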